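Notes on the amide ring series, cathepsin S inhibition

This account rests on a few compounds, and the source may have more. Where it says the series, first, only, none or still open, it means among the compounds named here.

Measured so far:
- compound 1 `C[C@@H]1CN(C(=O)[C@@H]2C[C@H](S(=O)(=O)c3ccccc3)C[C@H]2C(=O)NC2(C#N)CC2)C[C@H](C)O1`; in an assay on isolated protein for inhibition of cathepsin S (Homo sapiens), read by fluorescence, with a stated time of 20 min (a higher number here means a weaker inhibitor, a lower number a stronger inhibitor), compound 1 gives 0.4 nM
- compound 2 `N#CC1(NC(=O)[C@@H]2C[C@@H](S(=O)(=O)c3ccccc3)C[C@H]2C(=O)N2CCCCC2)CC1`; in this assay compound 2 gives 0.8 nM

For the measured compounds named here, compound 2 holds the higher of the two numbers measured in this assay so far; its only neighbour is compound 1, and the step of a 2.0-fold higher number from compound 1 to compound 2 (0.30 log units; within the scatter) separates them by no more than the usual scatter, so the two cannot be ranked against each other.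

Compound 3 `CC1CCN(C(=O)[C@@H]2C[C@H](S(=O)(=O)c3ccccc3)C[C@H]2C(=O)NC2(C#N)CC2)CC1` is not yet measured. It differs from compound 2 by methyl in place of hydrogen on a saturated ring carbon.

Going by the values given here, only one measured step bears on this change, and only loosely: the step from compound 1 to compound 2 exchanges the whole ring on the carbonyl, and it stayed within the scatter. Among the compounds with values here, no measured pair alters a substituent on the piperidin-1-yl ring itself, so the added methyl is untested. Given that even the ring exchange moved the number little, the expectation for compound 3 is a step of no change at the digits printed from compound 2 to compound 3 (within the scatter) in this assay, none beyond the scatter. The estimate for compound 3 is 0.8 nM, with a range from 0.3 nM to 2.5 nM.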

Compound 3, half-maximal inhibitory concentration: 0.5 nM
The estimate for compound 3 lay 1.6-fold (0.20 log units) above the measured number; the range from low to high includes it.
By their numbers in this assay, from the lowest: compounds 1, 3 and 2 (each within the scatter of the next).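

In this assay, for the compounds shown here, methyl in place of hydrogen on the saturated ring carbon, three ring bonds from the ring nitrogen, gives a step that stays within the scatter (a 1.6-fold lower number from compound 2 to compound 3 (0.20 log units; within the scatter)), so this position on the piperidin-1-yl ring, which no earlier pair altered, accepts a methyl with no readable change in the number. The exchange of 2,6-dimethylmorpholin-4-yl for 4-methylpiperidin-1-yl on the carbonyl carbon also stays within the scatter (a 1.3-fold higher number from compound 1 to compound 3 (0.10 log units; within the scatter)), which places all three amide rings within the scatter of one another, so compounds 1, 2 and 3 cannot be ranked among themselves. No supporting data bear on this tolerance of the methyl or of the ring exchange.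

The compounds shown leave open whether this ring carbon accepts anything beyond a methyl, such as a longer chain, a hydroxyl, an amine or a carboxylic acid, and how far the number can move at this place. They also leave open whether a methyl at any other carbon of the piperidin-1-yl ring would behave in the same way.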